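Hexyl in place of 4-chlorophenyl on a shared core

A few compounds are considered here, and "the series" means these few. Any claim that something is new, unique, unknown or untested is made for them only; others in the source may bear on it.

Three compounds have so far been measured in a functional assay on A549 cells (Homo sapiens) for cytotoxicity, read by MTT assay, with a stated time of 72 h; a higher number here means a weaker inhibitor, a lower number a stronger inhibitor:

Compound 1, `CCCCCOCNc1n[n+]([O-])c2ccccc2[n+]1[O-]`, gives 2900 nM in this assay.
Compound 2, `[O-][n+]1nc(NCOCc2ccc(Cl)cc2)[n+]([O-])c2ccccc21`, gives 2190 nM in this assay.
Compound 3, `[O-][n+]1nc(NCOCc2ccc(C(F)(F)F)cc2)[n+]([O-])c2ccccc21`, gives 4270 nM in this assay.

Compound 2 shows the lowest number of the three, but neither neighbour is separated from it by more than the scatter: the change a 1.3-fold lower number from compound 1 to compound 2 (0.12 log units; within the scatter) and the change a 1.9-fold higher number from compound 2 to compound 3 (0.29 log units; within the scatter) both fall inside the range that repeated measurements of this kind normally cover. On these numbers the three compounds cannot be told apart.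

Compound 4, `CCCCCCCOCNc1n[n+]([O-])c2ccccc2[n+]1[O-]`, has not yet been measured. It differs from compound 2 in one place: hexyl in place of 4-chlorophenyl on a saturated chain carbon bound to an oxygen on a saturated carbon. Among the measured compounds shown here, the one measured step that bears on this place is the exchange of butyl for 4-chlorophenyl, a 1.3-fold lower number from compound 1 to compound 2 (0.12 log units; within the scatter), which stayed within the scatter. For the measured compounds named here, the move to hexyl goes back from an aromatic ring to a plain chain, now longer than butyl; no measured step tells what lengthening the chain does. Going by the values given here, since the only comparable step was flat, compound 4 is expected to sit close to compound 2, with an estimated step of a 1.3-fold higher number from compound 2 to compound 4 (0.11 log units; within the scatter) and no change beyond the scatter. The estimated value for compound 4 in this assay is 2800 nM, with a range from 1200 nM to 6500 nM.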

Compound 4, half-maximal inhibitory concentration: 3490 nM
Compound 4: middle estimate off by 1.2-fold (0.10 log units), on the low side; the range from low to high includes it.
By their numbers in this assay, from the lowest: compounds 2, 1, 4 and 3 (each within the scatter of the next).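

In this assay, hexyl in place of 4-chlorophenyl gives a 1.6-fold higher number from compound 2 to compound 4 (0.20 log units; within the scatter) and stays within the scatter, so the plain chain and the aromatic ring cannot be told apart at this place, and this now holds for hexyl as well as for the butyl of compound 1. The earlier compounds shown here could not address chain length, and the new pair does: ethyl in place of hydrogen at the far end of the chain gives a 1.2-fold higher number from compound 1 to compound 4 (0.08 log units; within the scatter), also within the scatter, so these two chain lengths cannot be told apart either. No measurement here offers an explanation for these results.

All four compounds now lie within the scatter of their measured neighbours, so no group shown at this place separates clearly from the others, and what this position can tolerate remains unknown. A chain ending in an amine or a carboxylic acid, or a much longer chain such as dodecyl, would be a stronger test of whether any change at this place can move the number beyond the scatter.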